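Quinolin-5-yl in place of 4-cyanophenyl: working notes

The source may hold more compounds than are shown below. What is called first, only, known or untested is meant among the compounds shown, and "the series" means these compounds.

Measured in a physicochemical assay for solubility, in phosphate buffer, at pH 7.4; a lower number here means a less soluble compound, a higher number a more soluble compound:
- compound 1 `COCC1CCN(c2nccnc2OC2CN(c3ccc4ccccc4n3)C2)CC1`: 53000 nM
- compound 2 `OCc1cccc(-c2nccnc2OC2CN(c3ccc4ccccc4n3)C2)c1`: 29000 nM
- compound 3 `N#Cc1ccc(-c2nccnc2OC2CN(c3ccc4ccccc4n3)C2)cc1`: < 1000 nM (a limit, not a number)

Compound 3 stands at the limit of < 1000 nM in this assay, at which 1 of the 3 values shown sits, and gives no exact value. Compound 4 `c1ccc2nc(N3CC(Oc4nccnc4-c4cccc5ncccc45)C3)ccc2c1` carries quinolin-5-yl in place of 4-cyanophenyl on an aromatic carbon. Three measured steps change this same place. Two are large, an at least 53-fold lower number from compound 1 to compound 3 (1.72 log units; beyond the scatter) and an at least 29-fold lower number from compound 2 to compound 3 (1.46 log units; beyond the scatter), whereas a 1.8-fold lower number from compound 1 to compound 2 (0.26 log units; within the scatter) stays within the scatter. Compound 4 lacks the hydroxymethyl of compound 2 and the piperidine of compound 1, so in this assay it is expected to remain near compound 3, with at most a small rise. The expected change is an at least 1.8-fold higher number from compound 3 to compound 4 (0.25 log units; that floor lies within the scatter). A further reading at the limit is quite possible. The estimate for compound 4 is 1800 nM, with an expected range of 400 nM to 9000 nM.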

Compound 4, solubility: 47000 nM
Compound 4: middle estimate off by 26-fold (1.42 log units), on the low side, outside the stated range (above it).
By their numbers in this assay, from the lowest: compounds 2, 4 and 1 (each within the scatter of the next). At a limit, below all of these: compound 3.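

In this assay, the change to quinolin-5-yl gives an at least 47-fold higher number from compound 3 to compound 4 (1.67 log units; beyond the scatter), so a number level with those of the other two compounds is reached at this position without a hydroxymethyl or a piperidine. Quinolin-5-yl also stays level with both other groups: a 1.6-fold higher number from compound 2 to compound 4 (0.21 log units; within the scatter) and a 1.1-fold lower number from compound 1 to compound 4 (0.05 log units; within the scatter), leaving 4-cyanophenyl as the only group shown that stands apart. The reading for compound 3 is a limit, not a number: the limit of < 1000 nM in this assay, at which 1 of the 4 values shown sits.

Going by these compounds, whether the low reading goes with the nitrile or with the phenyl ring itself stays open. An unsubstituted phenyl or an aminophenyl could read like either compound 3 or compound 4.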